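This account rests on a few compounds, and the source may have more. Where it says the series, first, only, none or still open, it means among the compounds named here.

In a functional assay on KB cells (Homo sapiens) for cytotoxicity, read by sulforhodamine B assay, with a stated time of 3 days (a higher number here means that more compound is needed for the effect, a lower number that less compound is needed), compound 1 `Cc1coc(-c2ccc3c(c2O)CCCC3(C)C)c1C(=O)O` gives 4.7 uM, while compound 2 `COc1c(-c2occ(C)c2C(=O)O)ccc2c1CCCC2(C)C` gives 43.3 uM, the higher of the two numbers. Compound 3 `COCc1c(C)coc1-c1ccc2c(c1OC)CCCC2(C)C` carries methoxymethyl in place of carboxy on an aromatic carbon of compound 2: methoxymethyl in place of carboxy on an aromatic carbon. Among the compounds with values here, the only measured step, a 9.2-fold higher number from compound 1 to compound 2 (0.96 log units; beyond the scatter), put methyl in place of hydrogen on an oxygen at a different place, so it indicates neither the size nor the direction of this change. No shift beyond the scatter is therefore expected, though with wide uncertainty. The expected result is a 1.2-fold lower number from compound 2 to compound 3 (0.09 log units; within the scatter). The estimate for compound 3 is 35 uM, ranging from 10 uM to 100 uM.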

Compound 3, concentration for half-maximal effect: 11.5 uM
The estimate for compound 3 lay 3.0-fold (0.48 log units) above the measured number, and the stated range covers the measured number.
By their numbers in this assay, from the lowest: compound 1; then compound 3; then compound 2.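

In this assay, methoxymethyl in place of carboxy on this aromatic carbon gives a 3.8-fold lower number from compound 2 to compound 3 (0.58 log units; beyond the scatter) and so lowers the number beyond the scatter. With methyl on the ring oxygen-bearing side of the core, as in both compounds, carboxy and its hydrogen-bond donor are therefore not needed here for cytotoxicity in these cells. Nothing measured here accounts for this shift. Going by these compounds, whether an amine or a longer ether chain at this position would lower the number further remains open. So does whether the same change would act alike with hydrogen in place of that methyl, as in compound 1.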